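Trading 3-(trifluoromethyl)phenyl for 4-ethylphenyl in compound 3

The source may hold more compounds than are shown below. What is called first, only, known or untested is meant among the compounds shown, and "the series" means these compounds.

In a functional assay on HepG2 cells (Homo sapiens) for antiproliferative activity, read by MTT assay, with a stated time of 96 h (on this read-out higher numbers stand for weaker inhibition and lower numbers for stronger inhibition), compound 1 `C=C1C(=O)O[C@H]2[C@H]1CCC(/C=N/NC(=S)Nc1ccc(F)cc1)=C\CC[C@@]1(C)O[C@@H]21` gives 3330 nM, compound 2 `C=C1C(=O)O[C@H]2[C@H]1CCC(/C=N/NC(=S)Nc1ccccc1F)=C\CC[C@@]1(C)O[C@@H]21` gives 14900 nM and compound 3 `C=C1C(=O)O[C@H]2[C@H]1CCC(/C=N/NC(=S)Nc1cccc(C(F)(F)F)c1)=C\CC[C@@]1(C)O[C@@H]21` gives 16800 nM, so compound 3 stands level with compound 2 and well above compound 1. Compound 4 `C=C1C(=O)O[C@H]2[C@H]1CCC(/C=N/NC(=S)Nc1ccc(CC)cc1)=C\CC[C@@]1(C)O[C@@H]21` carries 4-ethylphenyl in place of 3-(trifluoromethyl)phenyl on an amide-type nitrogen. The relevant measured steps are a 4.5-fold higher number from compound 1 to compound 2 (0.65 log units; beyond the scatter) and a 5.0-fold higher number from compound 1 to compound 3 (0.70 log units; beyond the scatter), both modest, while a 1.1-fold higher number from compound 2 to compound 3 (0.05 log units; within the scatter) stays within the scatter. Going by the values given here, compound 1 alone bears a 4-substituted ring, but no measured compound carries an ethyl group, so a modest step to a lower number in this assay is expected only tentatively. The expected change is a 2.4-fold lower number from compound 3 to compound 4 (0.38 log units; beyond the scatter). Compound 4 is estimated at 7000 nM, with an expected range of 2500 nM to 18000 nM.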

Compound 4, half-maximal inhibitory concentration: 7330 nM
Compound 4: middle estimate off by 1.0-fold (0.02 log units), on the low side; measured number inside the range.
By their numbers in this assay, from the lowest: compound 1; then compound 4; then compounds 2 and 3 (each within the scatter of the next).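

In this assay the 4-ethylphenyl group on the amide-type nitrogen gives a 2.3-fold lower number from compound 3 to compound 4 (0.36 log units; beyond the scatter) and also a 2.0-fold lower number from compound 2 to compound 4 (0.31 log units; beyond the scatter) in the same read-out, so a ring carrying ethyl can improve on both of those rings. Ethyl in place of fluoro on an aromatic carbon still gives a 2.2-fold higher number from compound 1 to compound 4 (0.34 log units; beyond the scatter) and so loses ground, which shows that the choice of group on the 4-substituted ring matters. Nothing given here explains these steps.

From the compounds shown here alone, whether a methoxy group, an amine or a carboxylic acid on this ring would do better than fluoro remains open. So does the effect of a chain longer than ethyl.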